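From Dimethylcarbamoyl to Triazolyl on a Saturated Ring

The source may hold more compounds than are shown below. What is called first, only, known or untested is meant among the compounds shown, and "the series" means these compounds.

Of the compounds shown here, three sharing one core have been measured in an ADME assay on S9 fraction from liver (Rattus norvegicus) for metabolic stability, with a stated time of 1 h; a higher number here means that more of the compound is left, a lower number that less of the compound is left. Compound 1 `N#Cc1cnc(NCc2cnccc2C(F)(F)F)cc1N[C@H]1CC[C@@H](O)CC1` gives 6%, compound 2 `N#Cc1cnc(NCc2cnccc2C(F)(F)F)cc1N[C@H]1CC[C@@H](C(N)=O)CC1` gives 30%, and compound 3 `CN(C)C(=O)[C@H]1CC[C@@H](Nc2cc(NCc3cnccc3C(F)(F)F)ncc2C#N)CC1` gives 22%. Compound 3 therefore cannot be told apart from compound 2, while compound 1 lies clearly lower.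

Compound 4 `N#Cc1cnc(NCc2cnccc2C(F)(F)F)cc1N[C@H]1CC[C@@H](c2nc[nH]n2)CC1` has 1H-1,2,4-triazol-3-yl in place of dimethylcarbamoyl on a saturated ring carbon.

Among the compounds with values here, no measured compound carries this new group, so the guide is indirect. Changes at the same ring carbon gave modest steps, a number 24 percentage points higher from compound 1 to compound 2 (beyond the scatter) and a number 16 percentage points higher from compound 1 to compound 3 (beyond the scatter), each with hydroxy as the group replaced. The change between the two carbonyl-bearing groups, a number 8 percentage points lower from compound 2 to compound 3 (within the scatter), stayed within the scatter. With no evidence for a direction, no step beyond the scatter is expected, although the uncertainty is wide. The expected change is a number 2 percentage points lower from compound 3 to compound 4 (within the scatter). Compound 4 is estimated at 20%, with an expected range from 7% to 42%.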

Compound 4, percent of the compound remaining: 29%
Compound 4: the middle estimate sits 9 percentage points below what was measured; the measured number falls inside the stated range.
By their numbers in this assay, from the lowest: compound 1; then compounds 3, 4 and 2 (each within the scatter of the next).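

Read in this assay this position tolerates a five-membered aromatic ring as well as the two carbonyl-bearing groups: a number 7 percentage points higher from compound 3 to compound 4 (within the scatter) and a number 1 percentage points lower from compound 2 to compound 4 (within the scatter) leave the 1H-1,2,4-triazol-3-yl compound level with both amides. The difference from hydroxy also does not depend on a carbonyl being present, as a number 23 percentage points higher from compound 1 to compound 4 (beyond the scatter) shows, so all three replacements for hydroxy now stand clear of it while staying within the scatter of one another. Nothing shown here explains why these groups differ from hydroxy.

Still open, from the compounds shown here alone, is whether a tetrazole, an imidazole, a carboxylic acid or an amine on this ring carbon would fall with these three groups or with hydroxy. Also open, going by these compounds, is what a methyl group on the triazole ring would do.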